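This account rests on a few compounds, and the source may have more. Where it says the series, first, only, none or still open, it means among the compounds named here.

Compound 3 `CC(C)C[C@H](N)c1cc(C(F)(F)F)ccc1N1CCN(C(=O)CSc2ccc(Cl)cc2Cl)CC1` stands highest among the three numbers obtained so far in an assay on HEK293 cells for displacement of a labelled ligand from Melanocortin receptor 4 (Homo sapiens); on this read-out higher numbers stand for weaker inhibition and lower numbers for stronger inhibition; in this assay compound 3 gives 1500 nM. Nearest to it is compound 2 `CC(C)C[C@H](N)c1cc(C(F)(F)F)ccc1N1CCN(C(=O)C(C)Cc2ccc(Cl)cc2O)CC1`, which in this assay gives 36 nM, and furthest is compound 1 `COc1cc(Cl)ccc1C[C@@H](C)C(=O)N1CCN(c2ccc(C)cc2[C@@H](N)CC(C)C)CC1`, which in this assay gives 8.1 nM. Among the compounds with values here, the one measured step that touches the carbonyl carbon of the shared core is a 42-fold higher number from compound 2 to compound 3 (1.62 log units; beyond the scatter); it marks the move from a substituted benzyl-bearing group to the ((2,4-dichlorophenyl)sulfanyl)methyl group.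

Compound 4 `COc1cc(CC(C)C(=O)N2CCN(c3ccc(C(F)(F)F)cc3[C@@H](N)CC(C)C)CC2)ccc1Cl` has not yet been measured. Its difference from compound 3: 1-(4-chloro-3-methoxybenzyl)ethyl in place of ((2,4-dichlorophenyl)sulfanyl)methyl on a carbonyl carbon. This change largely reverses the measured step, since the entering 1-(4-chloro-3-methoxybenzyl)ethyl group is close to the groups carried by compound 2 and compound 1, both of which sit at the lower end of the numbers in this assay. A step of roughly the size seen between compound 2 and compound 3, but in the downward direction, is therefore expected, landing compound 4 in the region of compound 2 rather than compound 1, which differs in its core as well. Compound 4 is expected to give about 60 nM in this assay, within a range of 15 nM to 250 nM. The expected step is a 25-fold lower number from compound 3 to compound 4 (1.40 log units; beyond the scatter).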

Compound 4, inhibition constant: 230 nM
Beside the measured number, compound 4's estimate is 3.8-fold (0.58 log units) below it; low and high end bracket the measured number.
By their numbers in this assay, from the lowest: compound 1; then compound 2; then compound 4; then compound 3.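

In this assay, replacing the ((2,4-dichlorophenyl)sulfanyl)methyl group on the carbonyl carbon with 1-(4-chloro-3-methoxybenzyl)ethyl gives a 6.5-fold lower number from compound 3 to compound 4 (0.81 log units; beyond the scatter), so this branched benzyl-bearing chain recovers only part of the ground separating compound 3 from compound 2. The chain alone therefore does not set the number at this position: with the chain kept, 4-chloro-3-methoxyphenyl in place of 4-chloro-2-hydroxyphenyl gives a 6.4-fold higher number from compound 2 to compound 4 (0.81 log units; beyond the scatter), which shows that the aromatic group on the saturated chain carbon, two bonds along the chain from a carbonyl carbon, also counts in this series. No measurement among the compounds shown offers a reason for either step.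

The step from compound 2 to compound 4 changes both the oxygen substituent and its place on the ring, so the two contributions cannot be separated here; a 4-chloro-3-hydroxyphenyl group would begin to divide them. Also open, from the compounds shown here alone, is whether this position tolerates a quite different group on that ring, such as a carboxylic acid or an aminomethyl group, with the rest of compound 2 unchanged.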